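The source may report more compounds than this note shows. Statements on the series, on what has been measured and on what is new or still open speak of the compounds shown alone.

Of the compounds shown here, three built on one shared core have been tested in a functional assay on MGC-803 cells (Homo sapiens) for inhibition, read by MTT assay, with a stated time of 72 h; on this read-out higher numbers stand for weaker inhibition and lower numbers for stronger inhibition. Compound 1 `Cc1cc(Nc2cc(-c3ccccc3)[nH]n2)n2nc(SCc3c(Cl)cccc3Cl)nc2n1` gives 5280 nM, compound 3 `C#CCSc1nc2nc(C)cc(Nc3cc(-c4ccccc4)[nH]n3)n2n1` gives 13400 nM, and compound 2 `Cc1cc(Nc2ccn(Cc3nc(C)c4ccccc4n3)n2)n2nc(SCc3ccc(Br)cc3)nc2n1` gives 960 nM. Compound 2 therefore gives the lowest number of the three; the nearest to it is compound 1, and the furthest is compound 3, both gaps lying beyond the usual scatter. Among the measured compounds shown here, the only measured step between close neighbours, a 2.5-fold higher number from compound 1 to compound 3 (0.40 log units; beyond the scatter), is a modest loss of potency, and it concerns the group on the saturated chain carbon bound to a sulfur.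

Compound 4 `Cc1cc(Nc2ccn(Cc3csc4ccc(Cl)cc34)n2)n2nc(SCc3ccc(Br)cc3)nc2n1` has not yet been measured. It differs from compound 2 in another place: 5-chloro-1-benzothiophen-3-yl in place of 4-methylquinazolin-2-yl on a saturated chain carbon bound to an aromatic nitrogen. For the measured compounds named here, no measured pair changes this group on its own, since compounds 1 and 3 carry a different group there only together with further differences, so the step from compound 1 to compound 3 gives no direct guide. A step of uncertain direction, probably small, is therefore expected in this assay, and a 1.6-fold higher number from compound 2 to compound 4 (0.19 log units; within the scatter) expresses the expectation that the number stays near that of compound 2. The estimate for compound 4 is 1500 nM, with a range from 500 nM to 5000 nM.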

Compound 4, half-maximal inhibitory concentration: 1570 nM
The estimate for compound 4 lay 1.0-fold (0.02 log units) below the measured number; the range from low to high includes it.
By their numbers in this assay, from the lowest: compounds 2 and 4 (each within the scatter of the next); then compound 1; then compound 3.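

In this assay, among the compounds shown here, putting 5-chloro-1-benzothiophen-3-yl in place of 4-methylquinazolin-2-yl on a saturated chain carbon bound to an aromatic nitrogen gives a 1.6-fold higher number from compound 2 to compound 4 (0.21 log units; within the scatter) and this is the only direct reading of this place, with the rest of the molecule held the same. The two groups differ considerably: both ring nitrogens leave, a sulfur and a chlorine enter, a six-membered aromatic ring with hetero atoms gives way to a five-membered one with a single hetero atom, and the hydrogen-bond acceptor count changes, yet this assay does not separate the two compounds, so this place accepts at least this one exchange of two-ring aromatic groups. No measurement here explains that outcome.

The compounds shown leave open whether a much smaller or non-aromatic group on this chain carbon, such as a plain methyl, a morpholine ring or a carboxylic acid, would keep the number in this range. They also leave open whether the two groups would still match if the group on the saturated chain carbon bound to a sulfur were different.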